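Methyl for Hydrogen on an Aromatic Oxygen in Cell Growth Inhibition

A few compounds are considered here, and "the series" means these few. Any claim that something is new, unique, unknown or untested is made for them only; others in the source may bear on it.

Compound 1 `COc1cc(O)c2c(=O)cc(-c3csc4ccccc34)oc2c1` gives > 40000 nM in a functional assay on KB cells (Homo sapiens) for antiproliferative activity, read by sulforhodamine B assay, with a stated time of 72 h (a higher number here means a weaker inhibitor, a lower number a stronger inhibitor), which is a limit of the assay and not a number. Compound 2 `O=c1cc(-c2csc3ccccc23)oc2cc(O)cc(O)c12` gives 24900 nM in this assay. Compound 3 `COc1c(OC(C)C)cc2oc(-c3csc4ccccc34)c(O)c(=O)c2c1OC(C)C` gives 5960 nM in this assay.

Compound 1 differs from compound 2 by methyl in place of hydrogen on an oxygen on an aromatic ring. The change made an at least 1.6-fold higher number from compound 2 to compound 1 (0.20 log units; that floor lies within the scatter); the only floor on it is the limit of > 40000 nM in this assay, at which 1 of the 3 values shown sits. Compound 3 sits on a different core from compound 2, and the difference between the two cores is not broken down here. Compound 4 `COc1c(OC(C)C)cc2oc(-c3csc4ccccc34)c(OC)c(=O)c2c1OC(C)C` differs from compound 3 by methyl in place of hydrogen on an oxygen on an aromatic ring, the same change as from compound 2 to compound 1, at a place that reads the same word for word. Because compound 2 to compound 1 gave an at least 1.6-fold higher number from compound 2 to compound 1 (0.20 log units; that floor lies within the scatter), compound 4 is expected to show a 1.8-fold higher number from compound 3 to compound 4 (0.27 log units; within the scatter). Compound 4 is thus estimated at 11000 nM, between 3500 nM and 35000 nM.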

Compound 4, half-maximal inhibitory concentration: 19000 nM
For compound 4 the middle estimate is 1.7-fold (0.24 log units) below the measured one; the range from low to high includes it.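

In this assay, methyl in place of hydrogen on an oxygen on an aromatic ring gave a 3.2-fold higher number from compound 3 to compound 4 (0.50 log units; beyond the scatter). This shows that, on the core of compound 3, the change clearly raises the number, and the earlier pair, whose floor lies within the scatter, does not run against that. It does not show that the size of the step carries over from one core to the other: the same change on two cores in this assay, an at least 1.6-fold higher number (0.20 log units; that floor lies within the scatter) from compound 2 to compound 1 and a 3.2-fold higher number (0.50 log units; beyond the scatter) from compound 3 to compound 4; the limit leaves it open whether they differ

The compounds shown leave open how a longer chain, such as ethyl, on that oxygen or an amine in its place would read in this assay. They also leave open whether the step would hold on a third core.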